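Aryl amine variation on a shared core: cell growth inhibition

A few compounds are considered here, and "the series" means these few. Any claim that something is new, unique, unknown or untested is made for them only; others in the source may bear on it.

Measured compounds:
Compound 1 `Cc1n[nH]c2ccc(-c3nc4cnc(N5CCN(C)CC5)cn4c3Nc3cccc(F)c3)cc12` — 18.5%
Compound 2 `Cc1n[nH]c2ccc(-c3nc4cnc(N5CCN(C)CC5)cn4c3Nc3ccc(F)cc3)cc12` — 0%
Compound 3 `Cc1n[nH]c2ccc(-c3nc4cnc(N5CCN(C)CC5)cn4c3Nc3ccc(Cl)cc3F)cc12` — 0%

In a functional assay on MV4-11 cells (Homo sapiens) for inhibition, with a stated time of 120 h, tested at 10 uM (a higher number here means more inhibition at the concentration tested (going by the name of the read-out), a lower number less inhibition), compound 1 gives 18.5%. Among the measured compounds shown here, compound 2 stands level with compound 3 at the digits read, the two lowest of the three numbers; its only separation is from compound 1, a number 18.5 percentage points lower from compound 1 to compound 2 (beyond the scatter). Compound 4 `Cc1cc(Br)ccc1Nc1c(-c2ccc3[nH]nc(C)c3c2)nc2cnc(N3CCN(C)CC3)cn12`, not yet measured, differs from compound 2 by 4-bromo-2-methylphenyl in place of 4-fluorophenyl on a nitrogen on an aromatic ring.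

The step that bears most directly on this change is no change at the digits printed from compound 2 to compound 3 (within the scatter), where another exchange of the ring on that nitrogen left the number unchanged. Both a number 18.5 percentage points lower from compound 1 to compound 2 (beyond the scatter) and a number 18.5 percentage points lower from compound 1 to compound 3 (beyond the scatter) only show that compound 1 sits apart. For compound 4 the expected step is therefore a number 3 percentage points higher from compound 2 to compound 4 (within the scatter), none beyond the scatter. Compound 4 is estimated at 3%, with a range from 0% to 18%.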

Compound 4, a percentage reported as inhibition, at one concentration (the size of the read-out at that concentration, not a potency): 59.4%
Compound 4: middle estimate off by 56.4 percentage points, on the low side; measured number outside the range, above it.
By their numbers in this assay, from the lowest: compounds 2 and 3 (each within the scatter of the next); then compound 1; then compound 4.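

In this assay, among the compounds shown here, the change to 4-bromo-2-methylphenyl gives a number 59.4 percentage points higher from compound 2 to compound 4 (beyond the scatter) and a number 59.4 percentage points higher from compound 3 to compound 4 (beyond the scatter) and also a number 40.9 percentage points higher from compound 1 to compound 4 (beyond the scatter) so the ring on this nitrogen can move the read-out far beyond what the earlier compounds showed. The level result for compound 2 and compound 3 therefore did not mean that this position is insensitive. No measurement at hand accounts for the gain. Going by these compounds, whether the bromine or the methyl carries the step stays open, and 4-bromophenyl or 2-methylphenyl alone would separate the two. On these data alone, how a ring bearing an amine or a carboxylic acid would read here is also open.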